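The source may hold more compounds than are shown below. What is called first, only, known or untested is meant among the compounds shown, and "the series" means these compounds.

Working notes on the series. Among the measured compounds shown here, in a functional assay on HeLa cells (Homo sapiens) for inhibition (a lower number here means a stronger inhibitor, a higher number a weaker inhibitor), compound 1 `Cc1cn([C@H]2C[C@H](O)[C@@H](CO)O2)c(=O)n(/C=C/C=O)c1=O` gives 1 uM, the lowest of the three numbers so far. Compound 2 `O=C/C=C/n1c(=O)ccn(C2O[C@H](CO)[C@@H](O)[C@H]2O)c1=O` gives 9 uM, and compound 3 `O=C/C=C/n1c(=O)c(I)cn([C@H]2C[C@H](O)[C@@H](CO)O2)c1=O` gives 20 uM. For the measured compounds named here, the only single-point step measured, a 20-fold higher number from compound 1 to compound 3 (1.30 log units; beyond the scatter), lies beyond the scatter, and compound 1 stands beyond the scatter from compound 2 as well, so compound 1 is the strongest inhibitor of the three in this assay.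

The unmeasured compound 4 `Cc1cn([C@@H]2O[C@H](CO)[C@@H](O)[C@@H]2O)c(=O)n(/C=C/C=O)c1=O` differs from compound 1 in one place: hydroxy in place of hydrogen on a saturated ring carbon. Going by the values given here, no measured pair differs in exactly this way, so the step has no direct precedent. Compound 2 carries a hydroxy of this kind but also lacks the methyl, so the gap between compound 1 and compound 2 mixes two changes and can only be taken as a rough ceiling. The expectation for this assay is a moderate rise in the number, smaller than the gap to compound 2 at 9 uM but likely beyond the scatter. For compound 4 the estimated value in this assay is 3 uM, with a range from 1 uM to 9 uM. The expected step is a 3.0-fold higher number from compound 1 to compound 4 (0.48 log units; beyond the scatter).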

Compound 4, concentration for 50% inhibition: 40 uM
For compound 4 the middle estimate is 13-fold (1.12 log units) below the measured one, outside the stated range (above it).
By their numbers in this assay, from the lowest: compound 1; then compound 2; then compounds 3 and 4 (each within the scatter of the next).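

In this assay, the saturated ring carbon next to the ring atom that bears a hydroxy group is sensitive to substitution: hydroxy in place of hydrogen gives a 40-fold higher number from compound 1 to compound 4 (1.60 log units; beyond the scatter). Among the compounds shown here, this is the first single-point reading on the five-membered non-aromatic ring with 1 oxygen, and it shows that a large step in the direction of weaker inhibition can arise there as well as on the aromatic carbon, where iodo in place of methyl gives a 20-fold higher number from compound 1 to compound 3 (1.30 log units; beyond the scatter). Nothing available explains why this hydroxy raises the number.

The compounds shown leave open whether the step belongs to hydroxy itself or to any replacement of hydrogen on this carbon, a question that a fluorine, a methoxy or an amine at the same place would help to separate. Also open, on these data alone, is whether the step keeps its size when iodo replaces methyl on the aromatic carbon, as in compound 3.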